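Replacing the pyrazole with an aminophenyl on a fused core

The source may hold more compounds than are shown below. What is called first, only, known or untested is meant among the compounds shown, and "the series" means these compounds.

Compound 1 `COC(=O)c1sc2cc(-c3cnn(C)c3)cnc2c1N`: > 150000 nM
Compound 2 `COC(=O)c1sc2cc(-c3cnc4ccccc4c3)cnc2c1N`: 9500 nM

The two measured compounds share a core and differ only in the aryl group attached to it. In a functional assay on NCI-H460 cells (Homo sapiens) for inhibition, read by sulforhodamine B assay, with a stated time of 48 h (a lower number here means a stronger inhibitor of growth, a higher number a weaker inhibitor of growth), compound 1 gives > 150000 nM, which is a limit of the assay and not a number (the limit of > 150000 nM in this assay, at which 1 of the 2 values shown sits). In this assay compound 2 gives 9500 nM. Compound 1 therefore stands at the limit, and only compound 2 gives a measured value.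

Compound 3 `COC(=O)c1sc2cc(-c3ccc(N)cc3)cnc2c1N` is not yet measured. It differs from compound 1 in one place: 4-aminophenyl in place of 1-methyl-1H-pyrazol-4-yl on an aromatic carbon. Among the measured compounds shown here, no measured step between two compounds covers this change, so the expectation rests on the limit of compound 1 and the value of compound 2 alone. A step from compound 1 to compound 3 in this assay is expected to be toward stronger inhibition, though its size is uncertain, because compound 1 sits at the limit (the limit of > 150000 nM in this assay, at which 1 of the 2 values shown sits). Compound 3 is estimated at 40000 nM, with a range from 6000 nM to 150000 nM, an expected step of an at least 3.7-fold lower number from compound 1 to compound 3 (0.57 log units; beyond the scatter).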

Compound 3, concentration for 50% growth inhibition: 37100 nM
Compound 3: the middle estimate sits 1.1-fold (0.03 log units) above what was measured; low and high end bracket the measured number.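

At this aromatic carbon, two atoms from the ring nitrogen, 4-aminophenyl in place of 1-methyl-1H-pyrazol-4-yl gives an at least 4.0-fold lower number from compound 1 to compound 3 (0.60 log units; beyond the scatter) in this assay and yields a compound with a measured value. Among the compounds shown here, this is the only single change at this position that can be read so far, and it shows that a six-membered aromatic ring of carbon only, bearing an amine, is compatible with measurable growth inhibition here. On these data alone, the true size of the step stays open because compound 1 stands at a limit of the assay and not at a number: the limit of > 150000 nM in this assay, at which 1 of the 3 values shown sits.

The compounds shown leave open whether the step belongs to the carbon-only ring or to its amine, which an unsubstituted phenyl or a 4-hydroxyphenyl at this carbon would separate. They also leave open how a carboxylic acid or an amide in place of the methyl ester would behave in this assay.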